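Swapping a methyl for chloro on the phenol ring

The compounds below may be only part of what the source reports. "The series", "measured", "known", "first", "only" and "open" are said of these compounds alone.

Of the compounds shown here, two have been tested so far in a functional assay for inhibition, with Oryctolagus cuniculus as the target; on this read-out lower numbers stand for stronger inhibition and higher numbers for weaker inhibition. Compound 1 `COc1cccc(/C=C/C(C)=O)c1O` gives 3250 nM. Compound 2 `CC(=O)/C=C/c1cc(C)ccc1O` gives 8000 nM, the higher of the two numbers, and its gap to compound 1 is beyond the usual scatter. Compound 3 `CC(=O)/C=C/c1cc(Cl)ccc1O` is not yet measured; it differs from compound 2 by chloro in place of methyl on an aromatic carbon. With no comparable change seen among the measured pair, only a modest step is expected, and the estimated step in this assay is a 1.6-fold lower number from compound 2 to compound 3 (0.20 log units; within the scatter). Compound 3 is therefore expected to give about 5000 nM, within 2000 nM to 12000 nM.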

Compound 3, half-maximal inhibitory concentration: 60300 nM
Beside the measured number, compound 3's estimate is 12-fold (1.08 log units) below it, outside the stated range (above it).
By their numbers in this assay, from the lowest: compound 1; then compound 2; then compound 3.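

At the aromatic carbon para to the hydroxy group, the choice of group clearly matters: in this assay chloro in place of methyl gives a 7.5-fold higher number from compound 2 to compound 3 (0.88 log units; beyond the scatter) and so weaker inhibition. The swap exchanges one heavy atom for one and leaves the counts of hydrogen-bond donors, acceptors and net charge unchanged, yet the step lies beyond the scatter. No measurement here accounts for this difference. From the compounds shown here alone, what an amine or a longer chain on this carbon would do remains open, as does whether the same swap would behave alike on the core of compound 1.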